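A few compounds are considered here, and "the series" means these few. Any claim that something is new, unique, unknown or untested is made for them only; others in the source may bear on it.

Notes on the series. Compound 1 `O=c1oc(CO)cc2ccccc12` and compound 2 `O=C1OC(CO)Cc2ccccc21` are the two members run so far in a functional assay on HT-29 cells (Homo sapiens) for antiproliferative activity, read by sulforhodamine B assay, with a stated time of 48 h (on this read-out higher numbers stand for weaker inhibition of growth and lower numbers for stronger inhibition of growth), and both sit at the weak end of the scale. In this assay compound 1 gives 168 ug/mL. Compound 2 returns only a limit of the assay, >= 250 ug/mL, so no number stands for it. Taken together the two values show weak growth inhibition across the pair, and no single-point step connects them, so nothing more is read from their comparison. Compound 3 `COc1ccc2c(c1)C(=O)OC(CO)C2` is not yet measured; it differs from compound 2 by methoxy in place of hydrogen on an aromatic carbon. Going by the values given here, no measured step of this kind exists in the set, so the data give no direction for it; the step expected in this assay is an at least 1.0-fold lower number from compound 2 to compound 3 (0.03 log units; that floor lies within the scatter), none beyond the scatter. Compound 3 is accordingly expected near 230 ug/mL, within a range of 100 ug/mL to 400 ug/mL. Given (the limit of >= 250 ug/mL in this assay, at which 1 of the 2 values shown sits), a report of only a limit rather than a number for compound 3 is considered more likely than not.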

Compound 3, concentration for 50% growth inhibition: >= 250 ug/mL
Compound 3 gave a limit, no number; the forecaster's own chance of this, stated with the estimate: 60%; middle value at least 1.0-fold (0.03 log units) away from the limit.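

No step can be read between compound 2 and compound 3 in this assay, because each returns only a limit and not a number: the limit of >= 250 ug/mL in this assay, at which 2 of the 3 values shown sit.

The compounds shown leave open whether methoxy in place of hydrogen on an aromatic carbon changes growth inhibition at all.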